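The source may hold more compounds than are shown below. What is called first, only, known or untested is meant among the compounds shown, and "the series" means these compounds.

The shared core of compound 2, `Cc1ccc(-c2nn3c(-c4cc(Cl)cc(Cl)c4Cl)nnc3s2)cc1`, carries a 4-methylphenyl group on one side and a trichlorophenyl group on the other. In a functional assay on the whole organism with Rattus norvegicus as the target, read by paw edema, at a dose of 50 mg/kg by the oral route (a higher number here means more inhibition at the dose given (going by the name of the read-out), a lower number less inhibition), compound 2 gives 22.6%. Compound 1, `COc1ccc(C2=Nn3c(nnc3-c3cc(Cl)cc(Cl)c3Cl)SC2)cc1`, holds the same trichlorophenyl group on a related core and a methoxyphenyl group on the other side; in this assay compound 1 gives 19.4%. The two numbers lie within the usual scatter of each other, so compound 2 and compound 1 cannot be told apart on these data, and the inhibition in this assay is level between them.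

Compound 3, `Clc1cc(Cl)c(Cl)c(-c2nnc3sc(-c4ccncc4Br)nn23)c1`, differs from compound 2 in one place: 3-bromopyridin-4-yl in place of 4-methylphenyl on an aromatic carbon. Among the measured compounds shown here, no pair of measured compounds shows what such a swap does on this core, so there is no measured step to lean on. With both measured numbers close together, the expectation is that the change from compound 2 to compound 3 will be small, in no particular direction, and most likely within the scatter: an estimated step of a number 1.6 percentage points lower from compound 2 to compound 3 (within the scatter). Compound 3 is therefore expected to give about 21% in this assay, with a range from 8% to 36%.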

Compound 3, a percentage reported as inhibition, in the whole organism at one dose (the size of the read-out at that dose, not a potency): 19.4%
Compound 3: middle estimate off by 1.6 percentage points, on the high side; low and high end bracket the measured number.
By their numbers in this assay, from the lowest: compounds 1, 3 and 2 (each within the scatter of the next).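

In this assay, among the compounds shown here, putting 3-bromopyridin-4-yl in place of 4-methylphenyl on this aromatic carbon of the shared core gives a step of a number 3.2 percentage points lower from compound 2 to compound 3 (within the scatter), the first measured step at this position. The entering group brings a ring nitrogen and a bromine, yet the two compounds cannot be told apart at this single dose, so on this pair the position accepts a quite different six-membered aromatic ring with no readable difference in inhibition. Nothing measured here explains why the two compounds read alike.

The compounds shown keep an aromatic ring at this position, so it remains open whether a group of another kind there, such as an amine, a carboxylic acid or a longer chain, would also leave the inhibition level or would shift it beyond the scatter. The trichlorophenyl group on the other side of the core is also the same throughout, which leaves open what a plain phenyl or a single chlorine at that place would do.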